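Aryl swap on the sulfonamide of compound 3

The source may hold more compounds than are shown below. What is called first, only, known or untested is meant among the compounds shown, and "the series" means these compounds.

Three compounds with a shared core have been measured in a functional assay on 143B cells (Homo sapiens) for antiproliferative activity, read by MTT assay, with a stated time of 48 h; a lower number here means a stronger inhibitor, a higher number a weaker inhibitor:
compound 1 `O=C(Nc1cccc(/C=C/C(=O)c2nc3ccccc3[nH]2)c1)c1cccc(Br)c1`: 4620 nM
compound 2 `O=C(Nc1cccc(/C=C/C(=O)c2nc3ccccc3[nH]2)c1)c1cc(Cl)cc(Cl)c1`: 3660 nM
compound 3 `O=C(/C=C/c1cccc(NS(=O)(=O)c2ccccc2Cl)c1)c1nc2ccccc2[nH]1`: 4790 nM

Compound 3 sits together with the other two on these numbers: a 1.0-fold higher number from compound 1 to compound 3 (0.02 log units; within the scatter), and a 1.3-fold higher number from compound 2 to compound 3 (0.12 log units; within the scatter). Compound 4 `Cc1cc(C)cc(S(=O)(=O)Nc2cccc(/C=C/C(=O)c3nc4ccccc4[nH]3)c2)c1` is its sulfonamide counterpart with another aryl group: 3,5-dimethylphenyl in place of 2-chlorophenyl on a sulfonyl sulfur.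

Which measured steps bear on this? The closest is the swap of one aryl group for another on the carbonyl carbon, a 1.3-fold lower number from compound 1 to compound 2 (0.10 log units; within the scatter). The two steps that replace the whole carbonyl linkage by the sulfonyl linkage, with a different aryl ring at the same time, also stayed flat: a 1.0-fold higher number from compound 1 to compound 3 (0.02 log units; within the scatter) and a 1.3-fold higher number from compound 2 to compound 3 (0.12 log units; within the scatter). Every change tried so far in this small set, whether of the aryl ring or of the linker, has left the number where it was. For the measured compounds named here, there is no measured step in which an aryl swap on the sulfonyl sulfur itself is isolated, so the expectation rests on these three.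

Compound 4 is therefore expected to show no step beyond the scatter, a 1.1-fold lower number from compound 3 to compound 4 (0.03 log units; within the scatter). Compound 4 is estimated at 4500 nM, with a range from 1500 nM to 13000 nM.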

Compound 4, half-maximal inhibitory concentration: 3330 nM
Estimate against measurement, compound 4: 1.4-fold (0.13 log units) above; the measured number falls inside the stated range.
By their numbers in this assay, from the lowest: compounds 4, 2, 1 and 3 (each within the scatter of the next).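

In this assay, for the compounds shown here, the aryl swap on the sulfonyl sulfur gives a 1.4-fold lower number from compound 3 to compound 4 (0.16 log units; within the scatter), which isolates a change at this position for the first time and leaves it within the usual scatter. The sulfonamide series therefore behaves as the amide pair did under its own aryl swap, a 1.3-fold lower number from compound 1 to compound 2 (0.10 log units; within the scatter): 2-chlorophenyl, which carries a chlorine, and 3,5-dimethylphenyl, which is all carbon, cannot be told apart on this read-out, so neither the loss of the chlorine nor the entry of the two methyl groups registers as a step here. No measurement is available that would explain this lack of separation.

Going by these compounds alone, compounds 3 and 4 both place a six-membered aromatic ring of carbon only, with no hydrogen-bond donors or acceptors and no net charge, on the sulfonyl sulfur, so the flat result covers only that kind of group. Going by these compounds, whether an amine or a carboxylic acid on this ring, or a longer chain such as benzyl in place of the ring, would move the number beyond the scatter remains open.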